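From Cyclopropylcarbonyl to Propylsulfonyl on the Shared Core

The compounds below may be only part of what the source reports. "The series", "measured", "known", "first", "only" and "open" are said of these compounds alone.

Measured so far:
Compound 1 `CCCN1C(N)=NC(N)=NC12CCN(C(=O)C1CC1)CC2` gives > 100000 nM, a limit of the assay.
Compound 2 `CCCN1C(N)=NC(N)=NC12CCN(C(=O)NCCC(=O)OCC)CC2` gives > 100000 nM, a limit of the assay.

In an ADME assay on HeLa cells (Homo sapiens) for cytotoxicity, read by microscopy, with a stated time of 6 days (on this read-out higher numbers stand for lower toxicity in this test and lower numbers for higher toxicity in this test), compound 1 gives > 100000 nM; this is a limit of the assay and not a number. Compound 2 gives > 100000 nM in this assay, again only a limit. Among the compounds with values here, both values therefore sit at the limit of > 100000 nM in this assay, at which 2 of the 2 values shown sit, and the single measured step, a step that the two limits leave unreadable from compound 1 to compound 2, cannot be read in size or in direction.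

Compound 3 `CCCN1C(N)=NC(N)=NC12CCN(S(=O)(=O)CCC)CC2` differs from compound 1 in one place: propylsulfonyl in place of cyclopropylcarbonyl on an amine nitrogen in a ring. Within the data shown here, this change is not the one that was measured, and with the only measured step unreadable no size or direction can be taken from it. What bears on the expectation is simply that both measured compounds stand at the limit of this assay.

Compound 3 is therefore expected to give 150000 nM, within 60000 nM to 400000 nM, and most likely to be reported again only as a limit. The step that the limit leaves unreadable from compound 1 to compound 3 is thus the expected outcome, none beyond the scatter.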

Compound 3, minimum cytotoxic concentration: > 100000 nM
Compound 3: a limit, no number; the forecaster's own chance of this, stated with the estimate: 85%; the middle value does not contradict the limit.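

No step can be read from compound 1 to compound 3, since the results for compound 1, compound 2 and compound 3 in this assay are limits and not numbers: the limit of > 100000 nM in this assay, at which 3 of the 3 values shown sit.

The compounds shown leave open how far each lies beyond that limit, and whether any group on the amine nitrogen in a ring would give a numerical reading.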